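Swapping an Isopropyl for a Chlorophenyl Arm

This account rests on a few compounds, and the source may have more. Where it says the series, first, only, none or still open, it means among the compounds named here.

Measured compounds in an assay on microsomes for inhibition of 3-hydroxy-3-methylglutaryl-coenzyme A reductase (Rattus norvegicus); on this read-out lower numbers stand for stronger inhibition and higher numbers for weaker inhibition:
compound 1, `CCCCCCCCc1c(-c2ccccc2)sc(C(C)C)c1/C=C/[C@@H](O)C[C@@H](O)CC(=O)O`: compound 1 gives > 10000 nM
compound 2, `CC(C)c1sc(-c2ccccc2)c(-c2cccc(C(F)(F)F)c2)c1/C=C/[C@@H](O)C[C@@H](O)CC(=O)O`: compound 2 gives 2980 nM
compound 3, `CC(C)c1sc(C(C)C)c(-c2ccc(F)cc2)c1/C=C/[C@@H](O)C[C@@H](O)CC(=O)O`: compound 3 gives 26 nM

The value of compound 1 is a limit of this assay, not a number, as noted under (the limit of > 10000 nM in this assay, at which 1 of the 3 values shown sits). Among the two actual numbers, compound 3 stands lowest, and compound 2 sits well above it. For the measured compounds named here, the only single-point step that has been measured is an at least 3.3-fold lower number from compound 1 to compound 2 (0.52 log units; beyond the scatter), in which a 3-(trifluoromethyl)phenyl takes the place of an octyl on an aromatic carbon.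

Compound 4, `CC(C)c1sc(-c2ccc(Cl)cc2)c(-c2ccc(F)cc2)c1/C=C/[C@@H](O)C[C@@H](O)CC(=O)O`, has not yet been measured. It differs from compound 3 by 4-chlorophenyl in place of isopropyl on an aromatic carbon. Going by the values given here, no measured step touches this position or this kind of exchange, so the one measured step gives only a loose anchor: it shows that a change of a side group on the shared core can move this assay by a clear amount. Compound 3 is the closest relative and the best starting point.

For compound 4 the expected outcome is 80 nM, with a likely span from 20 nM to 400 nM. The estimated step is a 3.1-fold higher number from compound 3 to compound 4 (0.49 log units; beyond the scatter), a modest rise in the number that is expected rather than known.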

Compound 4, half-maximal inhibitory concentration: 21 nM
The estimate for compound 4 lay 3.8-fold (0.58 log units) above the measured number, within the range that was stated.
By their numbers in this assay, from the lowest: compounds 4 and 3 (each within the scatter of the next); then compound 2. At a limit, above all of these: compound 1.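

In this assay, placing 4-chlorophenyl instead of isopropyl on the aromatic carbon next to the ring sulfur gives a 1.2-fold lower number from compound 3 to compound 4 (0.09 log units; within the scatter). For the compounds shown here, no earlier step touched this position, and this one shows that it can carry a group of 7 heavy atoms with a six-membered aromatic ring as well as one of 3 heavy atoms with no ring, since compound 3 and compound 4 cannot be told apart on this read-out. Nothing available here accounts for this close match between such different groups.

This single exchange cannot show how much of the result depends on the ring itself and how much on its chlorine, and a plain phenyl group paired with the 4-fluorophenyl group of compound 4 would separate the two. It also leaves open whether this position would accept groups of quite a different kind, such as an amine, a carboxylic acid or a longer chain, so the match between these two compounds cannot be extended to substituents in general.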